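Sulfonamide aryl swap on a cathepsin S chalcone series

The source may report more compounds than this note shows. Statements on the series, on what has been measured and on what is new or still open speak of the compounds shown alone.

Compound 1: `Cc1cccc(C(=O)Nc2cccc(/C=C/C(=O)c3nc4ccccc4[nH]3)c2)c1` gives 45.2%
Compound 2: `O=C(/C=C/c1cccc(NS(=O)(=O)c2ccc(Cl)cc2)c1)c1nc2ccccc2[nH]1` gives 89.4%

In an assay on isolated protein for inhibition of cathepsin S (Homo sapiens), read by fluorescence, with stated times of 15 min and 30 min, tested at 5 uM (on this read-out lower numbers stand for less inhibition and higher numbers for more inhibition at the one concentration tested (going by the name of the read-out)), compound 2 stands highest of the two measured compounds; its nearest neighbour is compound 1, and the step of a number 44.2 percentage points higher from compound 1 to compound 2 (beyond the scatter) is large. Compound 3, `Cc1ccccc1S(=O)(=O)Nc1cccc(/C=C/C(=O)c2nc3ccccc3[nH]2)c1`, differs from compound 2 by 2-methylphenyl in place of 4-chlorophenyl on a sulfonyl sulfur. No measured step changes the aryl on the sulfonyl sulfur, so the one step shown, from carbonyl to sulfonyl, bears only loosely on it. In this assay compound 3 is therefore expected to stay near compound 2, with a modest drop of a number 11.4 percentage points lower from compound 2 to compound 3 (beyond the scatter) allowed for. The estimate for compound 3 is 78%, ranging from 50% to 95%.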

Compound 3, a percentage reported as inhibition, at one concentration (the size of the read-out at that concentration, not a potency): 47.8%
The estimate for compound 3 lay 30.2 percentage points above the measured number; measured number below the stated range.
By their numbers in this assay, from the lowest: compounds 1 and 3 (each within the scatter of the next); then compound 2.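

In this assay, the aryl on the sulfonyl sulfur proves decisive: 2-methylphenyl in place of 4-chlorophenyl gives a number 41.6 percentage points lower from compound 2 to compound 3 (beyond the scatter), so the sulfonyl alone does not carry the high number. Sulfonyl and carbonyl are also not separated with these aryls, as (2-methylphenyl)sulfonyl in place of (3-methylphenyl)carbonyl on the nitrogen gives a number 2.6 percentage points higher from compound 1 to compound 3 (within the scatter). Nothing available bears on the reason for either step.

The compounds shown leave open whether the chlorine, the methyl or both set the gap. A plain phenyl or a carboxylic acid on that aryl could help to separate these possibilities.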